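Methoxyphenyl in Place of Methylphenyl at the Side Chain

A few compounds are considered here, and "the series" means these few. Any claim that something is new, unique, unknown or untested is made for them only; others in the source may bear on it.

Three compounds built on one shared core differ only in the group carried on a saturated chain carbon bound to an aromatic carbon. In an in vitro functional assay on cells for agonist activity at Bombesin receptor subtype-3 (Homo sapiens), read by luminescence and calcium flux (a lower number here means that less compound is needed, a higher number that more compound is needed for the effect), compound 1 `O=C(O)c1ccccc1-c1ccc(CCc2ncc(CC3CCCC3)[nH]2)cc1` gives 133 nM, compound 2 `O=C(O)c1ccccc1-c1ccc(CCc2ncc(CCc3ccccc3)[nH]2)cc1` gives 1320 nM, and compound 3 `Cc1ccc(Cc2cnc(CCc3ccc(-c4ccccc4C(=O)O)cc3)[nH]2)cc1` gives 2660 nM. Compound 3 thus has the highest of the three numbers; its nearest neighbour is compound 2, separated by a 2.0-fold higher number from compound 2 to compound 3 (0.30 log units; within the scatter), while the widest gap in the set is a 20-fold higher number from compound 1 to compound 3 (1.30 log units; beyond the scatter). Compound 4 `COc1ccccc1Cc1cnc(CCc2ccc(-c3ccccc3C(=O)O)cc2)[nH]1` has not yet been measured in this assay. The change from compound 3 to compound 4 is 2-methoxyphenyl in place of 4-methylphenyl on a saturated chain carbon bound to an aromatic carbon. Going by the values given here, no measured step exchanges one aromatic substituent for another at this position: a 9.9-fold higher number from compound 1 to compound 2 (1.00 log units; beyond the scatter) and a 20-fold higher number from compound 1 to compound 3 (1.30 log units; beyond the scatter) both replace a saturated ring by an aromatic one, and a 2.0-fold higher number from compound 2 to compound 3 (0.30 log units; within the scatter) turns a benzyl into a 4-methylphenyl. The step that comes closest to the change in hand, from compound 2 to compound 3, lies within the scatter, so the step of a 1.2-fold lower number from compound 3 to compound 4 (0.08 log units; within the scatter) is expected to remain small, with no direction that goes beyond the scatter. Compound 4 is therefore estimated at 2200 nM, with a range from 700 nM to 7000 nM.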

Compound 4, half-maximal effective concentration: 1720 nM
Beside the measured number, compound 4's estimate is 1.3-fold (0.11 log units) above it, and the stated range covers the measured number.
By their numbers in this assay, from the lowest: compound 1; then compounds 2, 4 and 3 (each within the scatter of the next).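

In this assay, the exchange of one aromatic substituent for another on a saturated chain carbon bound to an aromatic carbon can now be read directly: a 1.5-fold lower number from compound 3 to compound 4 (0.19 log units; within the scatter), and the comparison with the benzyl group gives a 1.3-fold higher number from compound 2 to compound 4 (0.11 log units; within the scatter). So moving from 4-methylphenyl to 2-methoxyphenyl, which brings in an oxygen and one hydrogen-bond acceptor, does not separate these compounds, and compounds 2, 3 and 4 form one group within the scatter, while the cyclopentyl of compound 1 remains apart, with a 13-fold higher number from compound 1 to compound 4 (1.11 log units; beyond the scatter). Nothing among the available data explains either the closeness of the aromatic groups or the distance to the saturated ring.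

The compounds shown leave open whether the methoxy group and the methyl group would behave alike at a shared ring position, as a 4-methoxyphenyl or 2-methylphenyl group would show. They also leave open whether the advantage of compound 1 belongs to the cyclopentyl ring alone or extends to other saturated groups, such as a cyclohexyl ring, an open isobutyl chain or a group carrying an amine.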